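The compounds below may be only part of what the source reports. "The series", "measured", "known", "first", "only" and "open" are said of these compounds alone.

Measured compounds:
- compound 1 `CCCCCCCCOP(=O)(O)OCCSC(=S)N1CCCC1`: 69000 nM
- compound 2 `CCCCCCOP(=O)(O)OCCSC(=S)N1CCCC1`: 54000 nM

In a functional assay on MDA-MB-231 cells (Homo sapiens) for inhibition, read by MTT assay, with stated times of 18 h and 4 h (on this read-out lower numbers stand for stronger inhibition and higher numbers for weaker inhibition), compound 2 gives 54000 nM and compound 1 gives 69000 nM, so the two stand level within the usual scatter of repeated measurements. The next compound is compound 3 `CCCCCCCCCCCCCCCCOP(=O)(O)OCCSC(=S)N1CCCC1`, and the change is decyl in place of hydrogen on a saturated chain carbon, six bonds along the chain from an oxygen on an unsaturated carbon. For the measured compounds named here, only one measured step bears on it, at the same place in the chain: a 1.3-fold lower number from compound 1 to compound 2 (0.11 log units; within the scatter). That step lies within the scatter and involves only an ethyl group, so it gives no clear direction for a change as large as a decyl group. No step beyond the scatter is therefore expected in this assay, although the range must stay wide. The expected step is a 1.4-fold lower number from compound 2 to compound 3 (0.13 log units; within the scatter). For compound 3 the estimated value is 40000 nM, with an expected range of 13000 nM to 90000 nM.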

Compound 3, half-maximal inhibitory concentration: 69000 nM
Estimate against measurement, compound 3: 1.7-fold (0.24 log units) below; the range from low to high includes it.
By their numbers in this assay, from the lowest: compounds 2, 1 and 3 (each within the scatter of the next).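

In this assay, the decyl group on a saturated chain carbon, six bonds along the chain from an oxygen on an unsaturated carbon, gives (a 1.3-fold higher number from compound 2 to compound 3 (0.11 log units; within the scatter)), and octyl in place of hydrogen, eight bonds along the chain from that oxygen, gives (no change at the digits printed from compound 1 to compound 3 (within the scatter)). The earlier ethyl step covered only a small change, whereas these steps show that even adding 10 heavy atoms at this place leaves the number within the usual scatter, so compounds 1, 2 and 3 stand level. No supporting measurement speaks to why the chain length makes so little difference here.

The compounds shown cover only plain carbon chains, so it remains open whether an amine or a carboxylic acid at the chain end would fit the same picture. On these data alone, a much shorter chain, such as ethyl, and a ring at this place also remain open.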